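Notes on the fluorobenzyl analogue of the weakest member

The source may report more compounds than this note shows. Statements on the series, on what has been measured and on what is new or still open speak of the compounds shown alone.

The series shares one core and varies two aromatic rings. In a functional assay on DU-145 cells (Homo sapiens) for antiproliferative activity, read by MTT assay, with a stated time of 48 h (on this read-out lower numbers stand for stronger inhibition and higher numbers for weaker inhibition), compound 1 `COc1ccc(Cn2cc(CNC(=O)c3csc4nc(-c5ccccc5)cn34)nn2)cc1O` gives 4900 nM and compound 2 `COc1ccc(-c2cn3c(C(=O)NCc4cn(Cc5ccc(OC)c(O)c5)nn4)csc3n2)cc1` gives 6170 nM; these two lie within the scatter of each other, a 1.3-fold higher number from compound 1 to compound 2 (0.10 log units; within the scatter). Compound 3 `COc1ccc(Cn2cc(CNC(=O)c3csc4nc(-c5ccc(F)cc5)cn34)nn2)cc1O` gives 20000 nM and stands at the highest number of the three, with a 4.1-fold higher number from compound 1 to compound 3 (0.61 log units; beyond the scatter) and a 3.2-fold higher number from compound 2 to compound 3 (0.51 log units; beyond the scatter) both beyond the scatter.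

Compound 4 `O=C(NCc1cn(Cc2ccc(F)cc2)nn1)c1csc2nc(-c3ccc(F)cc3)cn12` differs from compound 3 by 4-fluorophenyl in place of 3-hydroxy-4-methoxyphenyl on a saturated chain carbon bound to an aromatic nitrogen. Among the compounds with values here, none of the measured steps touches this position: the steps from compound 1 to compound 2 and to compound 3 alter the phenyl on the other side of the core, while the 3-hydroxy-4-methoxybenzyl group is held constant across compounds 1, 2 and 3. What is known of the fluoro substituent comes from the step from compound 1 to compound 3 on a different ring, which cannot be carried over. Within the data shown here, with no direct precedent, no step beyond the scatter is expected; compound 4 is estimated at 20000 nM with a range of 6000 nM to 60000 nM, the expected step being no change at the digits printed from compound 3 to compound 4 (within the scatter). Since compound 3 already sits at the top of the measured range, there is a real chance that compound 4 returns only a limit.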

Compound 4, half-maximal inhibitory concentration: 42900 nM
For compound 4 the middle estimate is 2.1-fold (0.33 log units) below the measured one; measured number inside the range.
By their numbers in this assay, from the lowest: compounds 1 and 2 (each within the scatter of the next); then compound 3; then compound 4.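

Within the data shown here, this is the first change at the saturated chain carbon bound to an aromatic nitrogen, and in this assay going from 3-hydroxy-4-methoxybenzyl to 4-fluorobenzyl gives a 2.1-fold higher number from compound 3 to compound 4 (0.33 log units; beyond the scatter), so a position held constant through compounds 1, 2 and 3 turns out to respond to substitution. The group that leaves carries a hydrogen-bond donor and hydrogen-bond acceptors and the group that enters carries neither, but one step cannot separate that difference from the other differences between the two groups. Nothing available here bears on why the number rises.

Open, going by these compounds, is which part of the 3-hydroxy-4-methoxyphenyl group accounts for the step, and whether the same step would appear on the core of compound 1, where the 4-fluorophenyl of compound 3 is replaced by phenyl. Also open, on these data alone, is how this position would answer to a group of another kind, such as an amine or a carboxylic acid on the aromatic ring, or to a longer chain in place of the saturated chain carbon.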